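Swapping Bromo for Hydroxy in a Cell-Growth Series

The source may hold more compounds than are shown below. What is called first, only, known or untested is meant among the compounds shown, and "the series" means these compounds.

Four compounds built around an enone bearing a thioether arm were compared for their effect on cell growth. In a functional assay on DU-145 cells (Homo sapiens) for inhibition, read by trypan blue exclusion, with a stated time of 96 h (a lower number here means a stronger inhibitor of growth, a higher number a weaker inhibitor of growth), compound 2 `O=C(O)c1ccc(C(=O)/C(=C\c2ccc(Br)c([N+](=O)[O-])c2)SCc2ccc(Br)cc2)cc1` gives 1000 nM. Compound 1 `O=C(O)c1ccc(C(=O)/C(=C\c2ccc(O)c([N+](=O)[O-])c2)SCc2ccc(Br)cc2)cc1` differs from compound 2 only in the change (hydroxy in place of bromo on an aromatic carbon), and in this assay compound 1 gives 50000 nM, so the step is a 50-fold higher number from compound 2 to compound 1 (1.70 log units; beyond the scatter). Compound 3 `O=C(/C(=C\c1ccc(Br)cc1)SCc1ccc(F)cc1)c1ccc(Br)cc1` carries a different core; how its core differs from that of compound 2 is not broken down here. In this assay compound 3 gives 25000 nM, which is close to the number for compound 1 but far from compound 2.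

Compound 4 `O=C(/C(=C\c1ccc(O)cc1)SCc1ccc(F)cc1)c1ccc(Br)cc1` has not yet been measured. It differs from compound 3 by hydroxy in place of bromo on an aromatic carbon. This is the same kind of change as that from compound 2 to compound 1, not the same: there the place was also ortho to a nitro group, here it is not. Because of a 50-fold higher number from compound 2 to compound 1 (1.70 log units; beyond the scatter), compound 4 is expected to be a weaker inhibitor than compound 3, with the step estimated as a 6.0-fold higher number from compound 3 to compound 4 (0.78 log units; beyond the scatter). The estimated value for compound 4 is 150000 nM, expected to lie between 30000 nM and 1000000 nM.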

Compound 4, concentration for 50% growth inhibition: 10000 nM
Estimate against measurement, compound 4: 15-fold (1.18 log units) above; the measured number lies below the stated range.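

In this assay, the new pair gives a 2.5-fold lower number from compound 3 to compound 4 (0.40 log units; beyond the scatter), so the swap of bromo for hydroxy that weakened growth inhibition on the core of compound 2 modestly strengthens it on the core of compound 3. The result of this change therefore cannot simply be carried from one core to the other, and the two steps clearly differ: the same change on two cores in this assay, a 50-fold higher number (1.70 log units; beyond the scatter) from compound 2 to compound 1 and a 2.5-fold lower number (0.40 log units; beyond the scatter) from compound 3 to compound 4, 130-fold (2.10 log units) apart, beyond the scatter of two such steps

What this does not show is which feature of the cores decides the outcome: they differ in more than one place, the nitro group among them, and two pairs cannot separate those differences.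

From the compounds shown here alone, it remains open whether the nitro group alone accounts for the split, which would take a matched bromo and hydroxy pair on a single core with and without that group. Going by these compounds, it is also open whether another group in the same place, such as methoxy or an amine, would follow hydroxy on either core.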